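The compounds below may be only part of what the source reports. "The series", "measured", "known", "first", "only" and "open" are said of these compounds alone.

Of the compounds shown here, three of a shared core have been tested in a functional assay on HCT-116 cells (Homo sapiens) for cytotoxicity, read by sulforhodamine B assay, with a stated time of 48 h; a lower number here means a stronger inhibitor of growth, a higher number a weaker inhibitor of growth. Compound 1 `ClCc1cccc(Cn2cnc3c(Cl)nc(Cl)nc32)c1` gives 1620 nM in this assay. Compound 2 `ClCc1ccccc1Cn1cnc2ncnc(Cl)c21` gives 1510 nM in this assay, and compound 3 `ClCc1ccc(Cn2cnc3c(Cl)nc(Cl)nc32)cc1` gives 1700 nM in this assay. The three numbers sit close together: compound 2 has the smallest number of the three, but its gap to compound 1 and its gap to compound 3 both lie within the usual scatter of repeated measurements, so no order among them can be claimed.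

Compound 4 `ClCc1ccccc1Cn1cnc2nc(Cl)nc(Cl)c21` has not yet been measured in this assay. It arises from compound 2 through (chloro in place of hydrogen on an aromatic carbon). Compounds 1 and 3 already carry two chloro groups on the same six-membered ring, and their numbers fall beside the number of compound 2, so the added chloro group is not expected to move the number beyond the scatter. The step from compound 2 to compound 4 is therefore expected to be about a 1.0-fold lower number from compound 2 to compound 4 (0.00 log units; within the scatter). Compound 4 is estimated to give 1500 nM in this assay, with a likely range from 700 nM to 3200 nM.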

Compound 4, concentration for 50% growth inhibition: 1860 nM
Beside the measured number, compound 4's estimate is 1.2-fold (0.09 log units) below it, within the range that was stated.
By their numbers in this assay, from the lowest: compounds 2, 1, 3 and 4 (each within the scatter of the next).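

In this assay, going by these compounds alone, putting a chloro group on the aromatic carbon between two ring nitrogen atoms gives a 1.2-fold higher number from compound 2 to compound 4 (0.09 log units; within the scatter) and so offers the first direct test of this position, which no earlier pair of compounds isolated. At this carbon, hydrogen and chloro cannot be told apart by this growth read-out, as the step is no larger than the differences seen between repeated measurements. No measurement shown gives a reason for this result.

Only hydrogen and chloro are shown at this carbon, so it remains open whether an amine or a methoxy group there would give a number beyond the scatter. Going by these compounds, it is also open whether removing this chloro group from compound 1 or compound 3 would leave their numbers just as little changed.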